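A few compounds are considered here, and "the series" means these few. Any claim that something is new, unique, unknown or untested is made for them only; others in the source may bear on it.

For the measured compounds named here, in an ADME assay on microsomes from liver (Rattus norvegicus) for metabolic stability, read by LC-MS, using NADPH, with a stated time of 10 min, tested at 0.5 uM (on this read-out lower numbers stand for a less stable compound and higher numbers for a more stable compound), compound 1 `Cc1cc(-c2cc(Cl)c(OC[C@@](C)(N)CC(C)C)cn2)ccn1` gives 73% and compound 2 `Cc1cc(-c2cc(C)c(OC[C@@](C)(N)CC(C)C)cn2)ccn1` gives 72%, so compound 1 stands level with the only other measured compound. Compound 3 `CC(C)C[C@](C)(N)COc1cnc(-c2ccnc(Cl)c2)cc1Cl` keeps the core of compound 1 and differs by chloro in place of methyl on an aromatic carbon, a change from 2-methylpyridin-4-yl to 2-chloropyridin-4-yl. Going by the values given here, the one measured step that bears on this exchanges the same two groups in another place, in the opposite sense: a number 1 percentage points lower from compound 1 to compound 2 (within the scatter). Going by these compounds, no shift beyond the scatter is therefore expected, and the direction stays open. The expected step is a number 1 percentage points higher from compound 1 to compound 3 (within the scatter). Compound 3 is estimated at 74%, with a range of 60% to 86%.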

Compound 3, percent of the compound remaining: 98%
Beside the measured number, compound 3's estimate is 24 percentage points below it; the whole stated range lies below it.
By their numbers in this assay, from the lowest: compounds 2 and 1 (each within the scatter of the next); then compound 3.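

In this assay, chloro in place of methyl next to the ring nitrogen brings a number 25 percentage points higher from compound 1 to compound 3 (beyond the scatter) and so shows that this position responds to the exchange. The same two groups exchanged in the other place brought only a number 1 percentage points lower from compound 1 to compound 2 (within the scatter) and gave no sign of this, so the effect of the exchange depends on where it is made. Nothing shown gives a reason for this result.

Going by these compounds, whether other groups at this position, such as fluoro, methoxy or an amine, would give a similar number remains open. So does whether the rise with chloro holds when the other place carries methyl, as in compound 2.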